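Amide aryl variation on the shared core

The compounds below may be only part of what the source reports. "The series", "measured", "known", "first", "only" and "open" are said of these compounds alone.

Measured so far in a functional assay on HEK293 cells for agonist activity at D(4) dopamine receptor (Homo sapiens), read by FLIPR; on this read-out higher numbers stand for an effect only at larger amounts of compound and lower numbers for an effect already at smaller amounts:
compound 1 `O=C(CN1CCC(c2cccc[n+]2[O-])CC1)Nc1cccc(-c2ccccc2)c1` gives 360 nM;
compound 2 `O=C(CN1CCC(c2cccc[n+]2[O-])CC1)Nc1ccccc1F` gives 270 nM;
compound 3 `Cc1cc(F)ccc1NC(=O)CN1CCC(c2cccc[n+]2[O-])CC1` gives 60 nM.

Compound 3 stands lowest of the three numbers in this assay; compound 2 is nearest to it and compound 1 furthest, both of these gaps beyond the scatter. Going by the values given here, the single one-place step known so far is a 4.5-fold lower number from compound 2 to compound 3 (0.65 log units; beyond the scatter), a modest gain on going to the 4-fluoro-2-methylphenyl group.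

Compound 4 `O=C(CN1CCC(c2cccc[n+]2[O-])CC1)Nc1cccc(Cl)c1` is not yet measured. It differs from compound 3 in one place: 3-chlorophenyl in place of 4-fluoro-2-methylphenyl on an amide-type nitrogen. Among the compounds with values here, no measured step bears directly on this change. Within the data shown here, the only guidance is that compound 3 carries the group that produced the gain in the step from compound 2, and compound 4 gives that group up for a phenyl substituted in a different pattern; compound 1, which also carries a single group on its phenyl, gives 360 nM, well above compound 3. The expectation is therefore that compound 4 moves back toward the numbers of compounds 1 and 2 rather than improving, a step of about a 3.7-fold higher number from compound 3 to compound 4 (0.56 log units; beyond the scatter). Compound 4 is thus estimated at 220 nM, with a likely range of 70 nM to 700 nM.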

Compound 4, half-maximal effective concentration: 62 nM
Compound 4: middle estimate off by 3.5-fold (0.55 log units), on the high side; measured number below the stated range.
By their numbers in this assay, from the lowest: compounds 3 and 4 (each within the scatter of the next); then compounds 2 and 1 (each within the scatter of the next).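

In this assay the step to the 3-chlorophenyl group on the amide-type nitrogen is within the scatter (a 1.0-fold higher number from compound 3 to compound 4 (0.01 log units; within the scatter)), so the low number of compound 3 is not tied to the 4-fluoro-2-methylphenyl group. The same group stands clear of the 2-fluorophenyl group (a 4.4-fold lower number from compound 2 to compound 4 (0.64 log units; beyond the scatter)), a gap of similar size to the earlier gain from compound 2 to compound 3. Chloro in place of phenyl on an aromatic carbon also gives a step beyond the scatter (a 5.8-fold lower number from compound 1 to compound 4 (0.76 log units; beyond the scatter)), so a phenyl ring with one added group can reach the low numbers, while compounds 1 and 2 show that not every such group does.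

Going by these compounds, whether an amine, a carboxylic acid or a methoxy group on this phenyl would keep the number as low remains open. The compounds shown offer no measured reason for any of these steps.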